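Methoxy to chloro, with only limits to go on

The source may hold more compounds than are shown below. What is called first, only, known or untested is meant among the compounds shown, and "the series" means these compounds.

Compound 1 `COc1cc(OC)c(OC)cc1/C=C/COC(=O)/C=C/c1ccc(OC)c(OC)c1`: > 723 umol/kg (a limit)
Compound 2 `COc1ccc(/C=C/C(=O)OC/C=C/c2cc(OC)c(OC)cc2OC)cc1`: > 780 umol/kg (a limit)

In a functional assay on the whole organism (strain Kunming) with Mus musculus as the target, with a stated time of 0.5 h (on this read-out higher numbers stand for an effect only at larger amounts of compound and lower numbers for an effect already at smaller amounts), compound 2 gives > 780 umol/kg, which is a limit of the assay and not a number. Neither value shown gives compound 2 a numerical position. Compound 3 `COc1cc(OC)c(OC)cc1/C=C/COC(=O)/C=C/c1ccc(Cl)cc1` has chloro in place of methoxy on an aromatic carbon, para to a large group: chloro in place of methoxy on an aromatic carbon. Within the data shown here, the only measured step, a step that the two limits leave unreadable from compound 1 to compound 2, is hydrogen in place of methoxy on an aromatic carbon, so it offers no size or direction to carry over. The expected step, an at least 1.1-fold lower number from compound 2 to compound 3 (0.04 log units; that floor lies within the scatter), is therefore a loose estimate with no measured size behind it. Another limit is the likeliest report for compound 3. Should a number appear, compound 3 is estimated at 700 umol/kg, with an expected range of 200 umol/kg to 1200 umol/kg.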

Compound 3, dose for half-maximal effect: > 514 umol/kg
Compound 3: only a limit was reported; the forecaster's own chance of this, stated with the estimate: 70%; the middle value does not contradict the limit.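

Among these compounds, compound 1, compound 2 and compound 3 all carry only limits in this assay, so no step among them can be read, in size or in direction. The compounds shown leave open whether chloro in place of methoxy shifts the half-maximal dose at all.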